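The compounds below may be only part of what the source reports. "The series", "measured", "known", "first", "only" and "open" are said of these compounds alone.

Compound 1 `COc1c(/C=C2/C(=O)Nc3ccccc32)c2ccccc2n1-c1ccccc1` and compound 2 `O=C1Nc2ccccc2/C1=C\c1c(Cl)n(CCCc2ccccc2)c2ccccc12` share an overall shape but are built on two different cores; how those cores differ is not broken down here. In a functional assay on cells (Cancer cell lines, Homo sapiens) for cytotoxicity, with a stated time of 48 h (on this read-out lower numbers stand for stronger inhibition of growth and higher numbers for weaker inhibition of growth), compound 1 gives 4070 nM, while compound 2 gives 72400 nM, the highest number of the three measured compounds. Compound 3 `COc1c(/C=C2/C(=O)Nc3ccc(Cl)cc32)c2ccccc2n1-c1ccccc1` is made from compound 1 by a single change, (chloro in place of hydrogen on an aromatic carbon). In this assay compound 3 gives 24000 nM, so that change brought a 5.9-fold higher number from compound 1 to compound 3 (0.77 log units; beyond the scatter). The unmeasured compound 4 `O=C1Nc2ccc(Cl)cc2/C1=C\c1c(Cl)n(CCCc2ccccc2)c2ccccc12` is made from compound 2 by exactly the same change, (chloro in place of hydrogen on an aromatic carbon), at a place described in the same words as for compound 3. Among the compounds with values here, only one example of this change has been measured, and it sits on a different core, so it is taken as a guide rather than a rule. Still, the expectation is that compound 4 will follow compound 3 and show a weaker inhibition of growth than compound 2, with an estimated step of a 4.1-fold higher number from compound 2 to compound 4 (0.62 log units; beyond the scatter) in this assay, resting on the step seen from compound 1 to compound 3, a 5.9-fold higher number from compound 1 to compound 3 (0.77 log units; beyond the scatter). Because compound 2 already gives 72400 nM, a further rise may push the number toward the edge of what the assay can report. For compound 4 the estimate in this assay is 300000 nM, expected to lie between 100000 nM and 900000 nM.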

Compound 4, concentration for total growth inhibition: 23400 nM
For compound 4 the middle estimate is 13-fold (1.11 log units) above the measured one; the whole stated range lies above it.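

Putting a chloro in place of a hydrogen on an aromatic carbon did not act alike on the two cores in this assay. On the core of compound 2 the change gave a 3.1-fold lower number from compound 2 to compound 4 (0.49 log units; beyond the scatter), which runs opposite to the step on the core of compound 1, and the comparison of the two steps shows a real gap between them: the same change on two cores in this assay, a 5.9-fold higher number (0.77 log units; beyond the scatter) from compound 1 to compound 3 and a 3.1-fold lower number (0.49 log units; beyond the scatter) from compound 2 to compound 4, 18-fold (1.26 log units) apart, beyond the scatter of two such steps. Within the data shown here, this shows that the result of this change on one core cannot simply be carried over to the other, but it rests on only one measured pair per core, and the cores differ in more than one place, so it does not show which difference between them goes with the switch in direction.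

On these data alone, it remains open whether the split between the cores is specific to chloro, or whether a bromo, a methyl group or an amine in place of the same hydrogen would also move the numbers in opposite directions on the two cores. As far as these compounds go, it is also open whether replacing the chain on the core of compound 2 with a shorter chain, or with one carrying a carboxylic acid, would change the size or direction of the chloro step.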